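The source may hold more compounds than are shown below. What is called first, only, known or untested is meant among the compounds shown, and "the series" means these compounds.

Compound 1 `CCNc1cc(-c2ccc(NC(=O)Nc3cccc4ccccc34)cc2C)ccn1` gives > 30000 nM
Compound 2 `CCNc1cc(-c2ccc(NC(=O)Nc3ccc(C)cc3)cc2C(F)(F)F)ccn1` gives 27100 nM

Among the compounds with values here, in a functional assay on BT-483 cells (Homo sapiens) for cytotoxicity, read by MTT assay, with a stated time of 24 h (a lower number here means a stronger inhibitor, a higher number a weaker inhibitor), compound 2 gives 27100 nM as the only actual number so far. Compound 1 gives > 30000 nM as a limit of the assay and not a number. Compound 3 `CCNc1cc(-c2ccc(NC(=O)Nc3ccccc3Cl)cc2C(F)(F)F)ccn1` has yet to be measured. It keeps the rest of compound 2 and carries 2-chlorophenyl in place of 4-methylphenyl on an amide-type nitrogen. Within the data shown here, no measured step shows what such a change does in this assay and so no shift beyond the usual scatter is expected in either direction. The expected change is a 1.1-fold lower number from compound 2 to compound 3 (0.05 log units; within the scatter). The outcome could also be a limit of the assay and not a number. Compound 3 is estimated at 24000 nM with an expected span from 10000 nM to 50000 nM as its range.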

Compound 3, half-maximal inhibitory concentration: 20800 nM
For compound 3 the middle estimate is 1.2-fold (0.06 log units) above the measured one; measured number inside the range.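

In this assay, within the data shown here, the exchange of 4-methylphenyl for 2-chlorophenyl on the amide-type nitrogen gives the first measured step at this position: a 1.3-fold lower number from compound 2 to compound 3 (0.11 log units; within the scatter). Among these compounds, the earlier compounds offered no pair that differed in this one place, so this is the first reading of what a change here does. For this one exchange, which neither adds nor removes a hydrogen-bond donor or acceptor, the number does not move beyond the usual scatter.

From the compounds shown here alone, whether a group such as 4-aminophenyl or 4-carboxyphenyl on this nitrogen would shift the number beyond the scatter remains open. Compound 1 gives a limit and not a number, and it differs from compound 2 in more than one place, so it adds no step: the limit of > 30000 nM in this assay, at which 1 of the 3 values shown sits.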